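Methyl for Chloro: Estimating Compound 4 from Three Neighbours

The compounds below may be only part of what the source reports. "The series", "measured", "known", "first", "only" and "open" are said of these compounds alone.

Compound 1 `Cc1ccc2ncc(S(=O)(=O)c3ccc(F)cc3)c(N3CCC(C)CC3)c2c1`, compound 2 `CC1CCN(c2c(S(=O)(=O)c3ccc(F)cc3)cnc3ccc(Cl)cc23)CC1` and compound 3 `CC1CCN(c2c(S(=O)(=O)c3ccc(Cl)c(Cl)c3)cnc3ccc(Cl)cc23)CC1` were all tested in an assay on isolated protein for displacement of a labelled ligand from metabotropic glutamate receptor 5 (Homo sapiens), with a stated time of 60 min, tested at 1 uM; a higher number here means more inhibition at the concentration tested (going by the name of the read-out), a lower number less inhibition. Compound 1 gives 90%, compound 2 gives 89% and compound 3 gives 86%. Compound 2 and compound 1 differ by methyl in place of chloro on an aromatic carbon, a step of a number 1 percentage points higher from compound 2 to compound 1 (within the scatter). The cores of compound 2 and compound 3 differ by 3,4-dichlorophenyl in place of 4-fluorophenyl on a sulfonyl sulfur, a step of a number 3 percentage points lower from compound 2 to compound 3 (within the scatter). Among the compounds with values here, compound 4 `Cc1ccc2ncc(S(=O)(=O)c3ccc(Cl)c(Cl)c3)c(N3CCC(C)CC3)c2c1` has not yet been measured in this assay; it differs from compound 3 by methyl in place of chloro on an aromatic carbon, the same change as the one from compound 2 to compound 1, at the same place. The step from compound 3 to compound 4 is expected to be a number 1 percentage points higher from compound 3 to compound 4 (within the scatter), because the same change earlier gave a number 1 percentage points higher from compound 2 to compound 1 (within the scatter). Compound 4 is therefore estimated at 87%, expected to fall between 78% and 94%.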

Compound 4, a percentage reported as inhibition, at one concentration (the size of the read-out at that concentration, not a potency): 82%
Compound 4: the middle estimate sits 5 percentage points above what was measured; the range from low to high includes it.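

In this assay, methyl in place of chloro on an aromatic carbon gives a number 4 percentage points lower from compound 3 to compound 4 (within the scatter), and this step does not differ from its earlier counterpart: the same change on two cores in this assay, a number 1 percentage points higher (within the scatter) from compound 2 to compound 1 and a number 4 percentage points lower (within the scatter) from compound 3 to compound 4, 5 percentage points apart, within the scatter of two such steps. Likewise, 3,4-dichlorophenyl in place of 4-fluorophenyl on a sulfonyl sulfur gives a number 8 percentage points lower from compound 1 to compound 4 (within the scatter), and the two cores again do not separate: the same change on two cores in this assay, a number 3 percentage points lower (within the scatter) from compound 2 to compound 3 and a number 8 percentage points lower (within the scatter) from compound 1 to compound 4, 5 percentage points apart, within the scatter of two such steps. Both changes therefore carry across these two cores without a detectable difference, but since every step here is small enough to be scatter, this does not show that either change has a real effect or that the steps would add up the same way on any other core.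

The compounds shown leave open what an amine or a nitrile would do on that aromatic carbon. They also leave open what a methoxy group would do on the phenyl ring attached to the sulfonyl sulfur.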